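The source may hold more compounds than are shown below. What is called first, only, known or untested is meant among the compounds shown, and "the series" means these compounds.

Measured so far in an ADME assay on the whole organism (Mus musculus, strain CD-1) for pharmacokinetics, with a stated time of 6 h, at a dose of 10 mg/kg by the oral route (a lower number here means less compound in the circulation, a higher number more compound in the circulation at the dose given), for three compounds

Compound 1 `Cc1c(C(=O)N2CC[C@H](N)C2)nc(-c2ccc(C#N)c(F)c2)n1-c1ccc2nn(C)cc2c1` gives 80 ng.h/mL
Compound 2 `CN[C@H]1CCN(C(=O)c2nc(-c3ccc(C#N)c(F)c3)n(-c3ccc4nn(C)c(Cl)c4c3)c2C)C1` gives 640 ng.h/mL
Compound 3 `CN[C@H]1CCN(C(=O)c2nc(-c3ccc(C#N)c(F)c3)n(-c3cc4cn(C)nc4cc3F)c2C)C1` gives "not determined" (no result reported)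

Only two of these compounds have a number. Compound 2 stands highest at 640 ng.h/mL and compound 1 lies lower at 80 ng.h/mL with a gap beyond the usual scatter of repeated measurements. These two structures differ in more than one place, so their gap cannot be tied to any single change. Compound 3 adds nothing to the comparison, as its entry reads "not determined" (no result reported) and carries no number.

The next compound to be tested is compound 4 `CN[C@@H]1CCCN(C(=O)c2nc(-c3ccc(C#N)c(F)c3)n(-c3ccc4nn(C)c(Cl)c4c3)c2C)C1` and its difference from compound 2 is 3-(methylamino)piperidin-1-yl in place of 3-(methylamino)pyrrolidin-1-yl on a carbonyl carbon in one place. In words, 3-(methylamino)piperidin-1-yl stands in place of 3-(methylamino)pyrrolidin-1-yl on a carbonyl carbon. Among the compounds with values here, no measured pair here isolates this change, so the data offer no direct guide to its size or direction. The starting point is therefore compound 2 at 640 ng.h/mL and a wide range is warranted. The expected 1.2-fold lower number from compound 2 to compound 4 (0.07 log units; within the scatter) in this assay is no shift beyond the scatter. For compound 4 the estimated value is 550 ng.h/mL with an expected range from 200 ng.h/mL to 1500 ng.h/mL in this measurement.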

Compound 4, area under the concentration-time curve: 410 ng.h/mL
For compound 4 the middle estimate is 1.3-fold (0.13 log units) above the measured one; the measured number falls inside the stated range.
By their numbers in this assay, from the lowest: compound 1; then compounds 4 and 2 (each within the scatter of the next).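

In this assay, within the data shown here, the swap of 3-(methylamino)pyrrolidin-1-yl for 3-(methylamino)piperidin-1-yl on a carbonyl carbon gives a 1.6-fold lower number from compound 2 to compound 4 (0.19 log units; within the scatter), and this is the only change here that can be read on its own. With everything else in the molecule held the same, this position takes the six-membered ring in place of the five-membered one with no difference that can be told apart from the ordinary spread of repeated measurements. No supporting measurement bears on this result, so it remains a plain observation about these two compounds, with no explanation attached.

Still open, from the compounds shown here alone, is how far this tolerance extends, for instance whether a seven-membered azepane ring carrying the same methylamino group, or an open-chain 2-(methylamino)ethylamino group on the same carbonyl carbon, would stay level with these two compounds. A single pair also cannot show whether the same swap would give a similar result on a different core, so it offers no general rule for this position.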